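A few compounds are considered here, and "the series" means these few. Any claim that something is new, unique, unknown or untested is made for them only; others in the source may bear on it.

Measured compounds:
Compound 1, `Cc1cccc(-n2nncc2CN2C(=O)C3(C(C#N)=C(N)Oc4c3c3nc5ccccc5nc3c3ccccc43)c3ccccc32)c1` — in a functional assay on HCT-116 cells (Homo sapiens) for antiproliferative activity, read by MTT assay, with a stated time of 48 h (a lower number here means a stronger inhibitor, a higher number a weaker inhibitor), compound 1 gives > 50000 nM, which is a limit of the assay and not a number.
Compound 2, `N#CC1=C(N)Oc2c(N)cc3nc4ccccc4nc3c2C12C(=O)N(Cc1cnnn1-c1ccccc1Cl)c1ccccc12` — in this assay compound 2 gives > 50000 nM, again a limit and not a number.

Among the measured compounds shown here, compound 2 therefore stands at the limit of this assay, and the only other value shown sits there as well, (the limit of > 50000 nM in this assay, at which 2 of the 2 values shown sit). No order between compound 1 and compound 2 can be read from this; both simply failed to reach a measurable half-maximal inhibitory concentration within the tested range.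

Compound 3, `Cc1ccc(Cl)cc1-n1nncc1CN1C(=O)C2(C(C#N)=C(N)Oc3c(N)cc4nc5ccccc5nc4c32)c2ccccc21`, keeps the core of compound 2 and differs in one place: 5-chloro-2-methylphenyl in place of 2-chlorophenyl on an aromatic nitrogen. For the measured compounds named here, no step between measured compounds is available to size such a change in this assay, and the starting point is a limit rather than a number. The expectation is therefore no movement beyond the scatter, and most likely another limit. The expected step that the limit leaves unreadable from compound 2 to compound 3 is small. Compound 3 is estimated at 70000 nM, with a range from 20000 nM to 250000 nM.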

Compound 3, half-maximal inhibitory concentration: 37200 nM
Beside the measured number, compound 3's estimate is 1.9-fold (0.27 log units) above it, within the range that was stated.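

In this assay, among the compounds shown here, compound 3 gives 37200 nM, the first value that is a number and not a limit, so a substituted phenyl on this aromatic nitrogen of the five-membered ring with 3 nitrogen can give a readable result on the core of compound 2. Placing 5-chloro-2-methylphenyl in place of 2-chlorophenyl gives an at least 1.3-fold lower number from compound 2 to compound 3 (0.12 log units; that floor lies within the scatter), so this change has only a floor and no claim of a shift beyond the scatter can be made. The full size of the step remains unreadable, as one end of it rests on a limit: the limit of > 50000 nM in this assay, at which 2 of the 3 values shown sit.

The compounds shown do not separate any contribution of the 5-chloro group from that of the 2-methyl group, and compound 1 differs from compound 2 in more than one place, so it adds nothing to this comparison. From the compounds shown here alone, it also remains open how the result would respond at this position to a phenyl ring carrying an amine or a carboxylic acid, or to a longer alkyl chain in place of the phenyl ring.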